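Benzylphenyl urea series: amino replaces chloro on the core

The compounds below may be only part of what the source reports. "The series", "measured", "known", "first", "only" and "open" are said of these compounds alone.

The series shares a core carrying an amino group and a urea linked to a benzylphenyl group. Compound 1 is `Nc1nn(C(=O)Nc2ccc(Cc3ccccc3)cc2)c2ccccc12`. In a functional assay on HCC 2998 cells (Homo sapiens) for antiproliferative activity, read by sulforhodamine B assay, with a stated time of 48 h (on this read-out lower numbers stand for higher toxicity in this test and higher numbers for lower toxicity in this test), compound 1 gives only a limit, > 100000 nM. Compound 2, `Nc1nn(C(=O)Nc2ccc(Cc3ccccc3)cc2)c2ccc(Cl)cc12`, carries chloro in place of hydrogen on an aromatic carbon of that core. In this assay compound 2 likewise gives only a limit, > 100000 nM. The step that the two limits leave unreadable from compound 1 to compound 2 cannot be sized; both values sit at the limit of > 100000 nM in this assay, at which 2 of the 2 values shown sit, and compound 2 stands at that limit with no number of its own.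

Compound 3 is `Nc1ccc2c(c1)c(N)nn2C(=O)Nc1ccc(Cc2ccccc2)cc1`. It differs from compound 2 by amino in place of chloro on an aromatic carbon. For the measured compounds named here, the only measured step, a step that the two limits leave unreadable from compound 1 to compound 2, is unreadable, so the present change cannot be sized from it; the record holds two limits and nothing more. The expectation for compound 3 in this assay is that it again reaches only the limit. The step that the limit leaves unreadable from compound 2 to compound 3 is expected to stay within the scatter. Compound 3 is estimated at 150000 nM, within 50000 nM to 500000 nM.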

Compound 3, concentration lethal to 50% of the cells: 40900 nM
The estimate for compound 3 lay 3.7-fold (0.56 log units) above the measured number; measured number below the stated range.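

Amino on this aromatic carbon, meta to a fused ring and para to a fused ring, is the first change in the series to give a readable shift in this assay, with an at least 2.4-fold lower number from compound 2 to compound 3 (0.38 log units; beyond the scatter) and an at least 2.4-fold lower number from compound 1 to compound 3 (0.38 log units; beyond the scatter), both beyond the scatter and, on this read-out, toward higher toxicity. Hydrogen and chloro at this position could not be told apart, as the step between them cannot be read, whereas amino separates from both, and the same lower number is reached whichever of the two it replaces. Each step starts from a limit, so its full size stays unknown, and compound 3 is the only compound of the three with a number of its own: the limit of > 100000 nM in this assay, at which 2 of the 3 values shown sit.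

The compounds shown leave open whether a methylamino, dimethylamino or acetamido group, or a hydroxyl, on this carbon would also bring the value within range of measurement. They also leave open whether amino on another aromatic carbon of the shared core would give a number of the same order as compound 3.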